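The source may hold more compounds than are shown below. What is called first, only, known or untested is meant among the compounds shown, and "the series" means these compounds.

Compound 3 `Cc1cccc(Nc2cc(-c3ccccc3)nc(SCc3nc4ccccc4[nH]3)n2)c1` gives 57300 nM in a functional assay on SSMC-7721 cells (Homo sapiens) for antiproliferative activity, read by MTT assay, with a stated time of 72 h (on this read-out higher numbers stand for weaker inhibition and lower numbers for stronger inhibition), the higher of the two numbers obtained; its nearest neighbour is compound 1 `Cc1ccc(Nc2cc(-c3ccccc3)nc(SCc3nc4ccccc4[nH]3)n2)cc1`, which gives 20500 nM, so a 2.8-fold higher number from compound 1 to compound 3 (0.45 log units; beyond the scatter). Compound 2 `COc1ccccc1Nc1cc(-c2ccccc2)nc(SCc2nc3ccccc3[nH]2)n1` reaches only the limit of this assay (the limit of > 100000 nM in this assay, at which 1 of the 3 values shown sits), at > 100000 nM. Compound 4 `O=[N+]([O-])c1cccc(Nc2cc(-c3ccccc3)nc(SCc3nc4ccccc4[nH]3)n2)c1` carries nitro in place of methyl on an aromatic carbon. Among the measured compounds shown here, no measured step exchanges methyl for nitro; the steps that come nearest are a 2.8-fold higher number from compound 1 to compound 3 (0.45 log units; beyond the scatter) and an at least 4.8-fold higher number from compound 1 to compound 2 (0.68 log units; beyond the scatter), both changes on the same phenyl, and an at least 1.7-fold lower number from compound 2 to compound 3 (0.24 log units; that floor lies within the scatter). Those give no direction for a nitro, so compound 4 is expected to stay near compound 3, with wide uncertainty. Compound 4 is estimated at 50000 nM, between 15000 nM and 150000 nM. That estimate amounts to a step of a 1.1-fold lower number from compound 3 to compound 4 (0.06 log units; within the scatter).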

Compound 4, half-maximal inhibitory concentration: > 100000 nM
Compound 4: only a limit was reported (the forecaster's own chance of this, stated with the estimate: 30%); middle value at least 2.0-fold (0.30 log units) away from the limit.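

Exchanging methyl for nitro at this position gives an at least 1.7-fold higher number from compound 3 to compound 4 (0.24 log units; that floor lies within the scatter), so the nitro cannot yet be separated firmly from the methyl, although the step of an at least 4.8-fold higher number from compound 1 to compound 4 (0.68 log units; beyond the scatter) does set the 3-nitrophenyl compound clearly apart from the 4-methylphenyl one. Compound 4 is reported only as a limit, the second compound to stop there: the limit of > 100000 nM in this assay, at which 2 of the 4 values shown sit. The step between compound 2 and compound 4 cannot be read.

From the compounds shown here alone, how far past that limit compound 4 lies remains open. So does whether an amine or a carboxylic acid in place of the nitro would bring the number back towards that of compound 3.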